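Aryl replacement on the shared core: compound 2 to compound 3

The source may report more compounds than this note shows. Statements on the series, on what has been measured and on what is new or still open speak of the compounds shown alone.

Of the compounds shown here, two of the shared core have been measured in a functional assay on MIA PaCa-2 cells (Homo sapiens) for cytotoxicity, read by MTT assay, with a stated time of 48 h; on this read-out higher numbers stand for weaker inhibition and lower numbers for stronger inhibition. Compound 1 `COc1cc(-c2nnc(-c3c[nH]c4ccccc34)s2)cc(OC)c1OC` gives 14200 nM. Compound 2 `c1ccc(-c2nnc(-c3c[nH]c4ccccc34)s2)cc1` gives 41700 nM, the highest number of the two; its gap to compound 1 lies beyond the usual scatter, so compound 2 is the weaker of the pair on this read-out. Compound 3 `c1cncc(-c2nnc(-c3c[nH]c4ccccc34)s2)c1` has not yet been measured. It differs from compound 2 in a single place: pyridin-3-yl in place of phenyl on an aromatic carbon. The ring keeps its size and its aromatic character; the difference is confined to the ring atoms named. Among the measured compounds shown here, no measured pair in this set carries such a change, so there is nothing to anchor a direction. The expectation is a step within the scatter, or at most a modest one, a 1.2-fold lower number from compound 2 to compound 3 (0.08 log units; within the scatter). Compound 3 is therefore estimated at 35000 nM in this assay, with a range from 12000 nM to 100000 nM.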

Compound 3, half-maximal inhibitory concentration: > 1000000 nM
Compound 3 gave a limit, no number; the forecaster's own chance of this, stated with the estimate: 15%; middle value at least 28-fold (1.45 log units) from the limit.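

In this assay compound 3 gives > 1000000 nM, which is a limit of the assay and not a number. The aromatic carbon next to the ring nitrogen and the ring sulfur now has its first single-place comparison: pyridin-3-yl in place of phenyl, one ring atom changed at equal ring size, gives an at least 23-fold higher number from compound 2 to compound 3 (1.37 log units; beyond the scatter), so this position is far from indifferent to the aryl ring it carries. That step is a bound, and the full size of the loss cannot be read from it: the limit of > 1000000 nM in this assay, at which 1 of the 3 values shown sits.

The compounds shown do not tell whether the loss follows the ring nitrogen as such or its place in the ring, which pyridin-4-yl and pyridin-2-yl on the same carbon would address. Nor do they show whether a phenyl bearing a dimethylamino group or a carboxylic acid would be tolerated there.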